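The source may hold more compounds than are shown below. What is called first, only, known or untested is meant among the compounds shown, and "the series" means these compounds.

In a functional assay, read by spectrophotometry, with a stated time of 30 min (a higher number here means that more compound is needed for the effect, a lower number that less compound is needed), compound 1 (`COc1cc(C2Oc3cc([C@H]4Oc5cc(O)cc(O)c5C(=O)[C@@H]4O)ccc3OC2COC(=O)c2cc(OC)c(OC)c(OC)c2)ccc1O`) gives 94800 nM as a measured number. Compound 2 (`COc1cc(C2Oc3cc([C@H]4Oc5cc(O)cc(O)c5C(=O)[C@@H]4O)ccc3OC2COC(=O)c2ccc([N+](=O)[O-])cc2)ccc1O`) gives > 300000 nM in this assay as a limit of the assay and not a number, so its standing is known only as a limit. Compound 3 (`COc1cc(C2Oc3cc([C@H]4Oc5cc(O)cc(O)c5C(=O)[C@@H]4O)ccc3OC2COC(=O)c2cc(N)cc([N+](=O)[O-])c2)ccc1O`) carries 3-amino-5-nitrophenyl in place of 4-nitrophenyl on a carbonyl carbon. Among the compounds with values here, the one measured step at this carbonyl carbon is an at least 3.1-fold higher number from compound 1 to compound 2 (0.50 log units; beyond the scatter) with 4-nitrophenyl in place of 3,4,5-trimethoxyphenyl. That step is at least modest but open-ended, and it sets no size for the new change. In this assay the expected step is an at least 1.3-fold lower number from compound 2 to compound 3 (0.13 log units; that floor lies within the scatter) and no shift beyond the scatter is expected. Compound 3 is estimated at 220000 nM (70000 nM to 600000 nM).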

Compound 3, half-maximal effective concentration: > 300000 nM
Compound 3 was reported as a limit; the forecaster's own chance of this, stated with the estimate: 45%; middle value at least 1.3-fold (0.13 log units) away from the limit.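

In this assay compound 3 gives > 300000 nM, which is a limit of the assay and not a number, so 3-amino-5-nitrophenyl in place of 4-nitrophenyl on this carbonyl carbon does not bring a measured number back. The replacement of 3,4,5-trimethoxyphenyl by 3-amino-5-nitrophenyl gives an at least 3.1-fold higher number from compound 1 to compound 3 (0.50 log units; beyond the scatter), so both nitro-bearing groups shown at this place read in the same direction from compound 1. The steps between compound 2 and compound 3 cannot be read, because both compounds sit at the same ceiling: the limit of > 300000 nM in this assay, at which 2 of the 3 values shown sit.

As far as these compounds go, the true sizes of the losses for compound 2 and compound 3 remain open, and so does any ranking of the two. Also open, from the compounds shown here alone, is how a plain phenyl, a 3,5-diaminophenyl or a 3,4-dimethoxyphenyl on this carbonyl carbon would read against compound 1 at 94800 nM.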